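The compounds below may be only part of what the source reports. "The series", "measured", "known", "first", "only" and "open" are said of these compounds alone.

Measured so far:
Compound 1, `CC[C@@H](NC(=O)CC(C)(C)N)C(=O)N(Cc1ccc(-c2ccccc2-c2nn[nH]n2)cc1)c1ccccc1`: 11 uM in a functional assay (Pituitary gland cell) with Rattus norvegicus as the target; on this read-out higher numbers stand for an effect only at larger amounts of compound and lower numbers for an effect already at smaller amounts
Compound 2, `CC(C)(N)CC(=O)N[C@H](CCc1ccccc1)C(=O)NCc1ccc(-c2ccccc2-c2nn[nH]n2)cc1`: 0.2 uM in this assay
Compound 3, `CCN(Cc1ccc(-c2ccccc2-c2nn[nH]n2)cc1)C(=O)[C@@H](CCc1ccccc1)NC(=O)C(C)(C)N`: > 0.5 uM in this assay

For compound 3 the result in this assay is a limit, not a number (the limit of > 0.5 uM in this assay, at which 1 of the 3 values shown sits), so it cannot be placed exactly against the other two. Compound 4, `CN(Cc1ccc(-c2ccccc2-c2nn[nH]n2)cc1)C(=O)[C@@H](CCc1ccccc1)NC(=O)C(C)(C)N`, differs from compound 3 by hydrogen in place of methyl on a saturated chain carbon bound to an amide-type nitrogen. Going by the values given here, no measured pair shows this same change, so its effect is open. Compound 2 gives 0.2 uM and compound 1 gives 11 uM in this assay, yet each differs from compound 3 in more than one place. The step from compound 3 to compound 4 is expected to be small, a step that the limit leaves unreadable from compound 3 to compound 4. Compound 4 is expected near 1 uM, within 0.3 uM to 5 uM.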

Compound 4, concentration for half-maximal effect: 0.03 uM
The estimate for compound 4 lay 33-fold (1.52 log units) above the measured number, and the stated range ends above it.
By their numbers in this assay, from the lowest: compound 4; then compound 2; then compound 1.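

Hydrogen in place of methyl on a saturated chain carbon bound to an amide-type nitrogen, which reads as ethyl to methyl, removes a single carbon, yet in this assay it gives an at least 16-fold lower number from compound 3 to compound 4 (1.22 log units; beyond the scatter). Going by these compounds alone, this position therefore responds strongly to a very small change, something no earlier pair could show. The true size of the step stays unknown, since compound 3 has only a limit: the limit of > 0.5 uM in this assay, at which 1 of the 4 values shown sits.

Two compounds give no trend along this chain. Going by these compounds, how a propyl chain or a carboxylic acid at this place would behave remains open.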